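From 4-chlorophenyl to 5-chloro-2-hydroxyphenyl on a carbonyl carbon

The source may report more compounds than this note shows. Statements on the series, on what has been measured and on what is new or still open speak of the compounds shown alone.

compound 1 `COc1cc(OC)c(OC)cc1/C=C/C(=O)c1ccc(Cl)cc1` gives 2.3 ug/mL
compound 2 `COc1cc(OC)c(-c2cc(=O)c3ccc(O)cc3o2)cc1OC` gives 2.15 ug/mL
compound 3 `COc1cc(OC)c(OC)cc1/C=C/C(=O)c1cc(Cc2ccccc2)cc(Cc2ccccc2)c1` gives 2.17 ug/mL

All three values come from a functional assay on cells (Erythrocyte, Rattus norvegicus) for inhibition, read by hemolysis, with a stated time of 1 h (a lower number here means a stronger inhibitor, a higher number a weaker inhibitor), and lie within the scatter of one another, so compound 1 (2.3 ug/mL) stands level with compound 2 and compound 3 rather than apart from them. Compound 4 `COc1cc(OC)c(OC)cc1/C=C/C(=O)c1cc(Cl)ccc1O` has not yet been measured. Against compound 1 its one change is 5-chloro-2-hydroxyphenyl in place of 4-chlorophenyl on a carbonyl carbon and the rest of the structure stays as it is. Within the data shown here, no two measured compounds differ in a single place, so the data offer no step to carry over. They show only a narrow band, with compound 2 at 2.15 ug/mL and compound 3 at 2.17 ug/mL in the same range. Compound 4 is therefore expected to fall inside that band, with no step beyond the scatter in this assay in either direction. The estimated change is a 1.1-fold lower number from compound 1 to compound 4 (0.04 log units; within the scatter) and it is expected to stay within the scatter. Compound 4 is estimated at 2.1 ug/mL with a range of 1 ug/mL to 4.5 ug/mL as the expected span.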

Compound 4, half-maximal inhibitory concentration: 2.23 ug/mL
For compound 4 the middle estimate is 1.1-fold (0.03 log units) below the measured one, and the stated range covers the measured number.
By their numbers in this assay, from the lowest: compounds 2, 3, 4 and 1 (each within the scatter of the next).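

In this assay, among these compounds, the exchange of 4-chlorophenyl for 5-chloro-2-hydroxyphenyl on a carbonyl carbon gives a 1.0-fold lower number from compound 1 to compound 4 (0.01 log units; within the scatter), the first single-place step in this set. The earlier compounds shown here offered only a narrow band of values, whereas this step shows directly that this position can take the entering group, with its hydroxy, without a step beyond the scatter. No supporting measurement bears on this result.

Because the hydroxy and the changed place of the chlorine arrive together, the compounds shown leave open what each would do alone, including whether their contributions offset each other. Also open, from the compounds shown here alone, is whether an amine or a carboxylic acid on this ring would give a step beyond the scatter.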